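Lengthening the acid chain on the pyridinone series

The compounds below may be only part of what the source reports. "The series", "measured", "known", "first", "only" and "open" are said of these compounds alone.

In an assay on HEK293 cells for displacement of a labelled ligand from chemoattractant receptor-homologous molecule expressed on Th2 cells (Cavia porcellus), read by scintillation counting, with a stated time of 2 h (a lower number here means a stronger inhibitor, a higher number a weaker inhibitor), compound 1 `O=C(O)COc1cccc(CCCn2cc(C(c3ccccc3)c3ccccc3)ccc2=O)c1` gives 256 nM. Going by the values given here, this is the higher of the two numbers recorded so far; the other compound, compound 2 `O=C(O)COc1cccc(CCCN(CCC(c2ccccc2)c2ccccc2)C(=O)c2ccccc2)c1`, gives 18 nM in this assay, and the gap between the two lies beyond the scatter, though they differ in more than one place and no single step connects them. Compound 3 `O=C(O)CCCOc1cccc(CCCn2cc(C(c3ccccc3)c3ccccc3)ccc2=O)c1` keeps the core of compound 1 and differs from it in one place: 2-carboxyethyl in place of carboxy on a saturated chain carbon bound to an oxygen on an aromatic ring. Among the compounds with values here, no measured pair shows what this change does in this assay. Within the data shown here, a modest rise in the number, somewhat beyond the scatter, is the expected step of a 2.3-fold higher number from compound 1 to compound 3 (0.37 log units; beyond the scatter) in this assay, because compound 1 gives 256 nM and nothing among the measured compounds points to a gain from a longer acid chain. Compound 3 is therefore estimated at 600 nM, expected within 150 nM to 2500 nM.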

Compound 3, half-maximal inhibitory concentration: 99 nM
Beside the measured number, compound 3's estimate is 6.1-fold (0.78 log units) above it; the measured number lies below the stated range.
By their numbers in this assay, from the lowest: compound 2; then compound 3; then compound 1.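

Going by these compounds alone, at this position, on a saturated chain carbon bound to an oxygen on an aromatic ring, the change from carboxymethoxy to 3-carboxypropoxy in this assay gives a 2.6-fold lower number from compound 1 to compound 3 (0.41 log units; beyond the scatter) and is the first single-place step available in this set. It shows that the carboxylic acid need not stay on the shorter chain for binding to be kept here, and that lengthening the chain brings a modest gain on the core of compound 1. No measurement at hand accounts for this gain.

The compounds shown leave open whether the gain continues, levels off or reverses with a still longer chain such as 4-carboxypropyl's next homologue, 4-carboxybutyl. They also leave open whether 3-carboxypropoxy brings a similar gain on the core of compound 2.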